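The source may report more compounds than this note shows. Statements on the series, on what has been measured and on what is new or still open speak of the compounds shown alone.

Compound 1 `CC(=O)Oc1ccc2c(c1)C(C)=CC(C)(C)N2Cc1ccc(C#N)cc1`: 29000 nM
Compound 2 `CC(=O)Oc1ccc2c(c1)C(C)=CC(C)(C)N2Cc1ccc(Cl)c(Cl)c1`: 28000 nM
Compound 3 `COc1cccc(CN2c3ccc(OC(C)=O)cc3C(C)=CC2(C)C)c1`: 29000 nM

In an ADME assay on L6 cells (Rattus norvegicus) for cytotoxicity, read by resazurin assay, with a stated time of 70 h (a lower number here means a stronger inhibitor, a higher number a weaker inhibitor), compound 1 gives 29000 nM, level with compound 3 at 29000 nM and within the scatter of compound 2 at 28000 nM. The three compounds share one core and differ only in the substituted phenyl group on the saturated chain carbon.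

The next compound, compound 4 `CC(=O)Oc1ccc2c(c1)C(C)=CC(C)(C)N2Cc1ccc(C(C)(C)C)cc1`, keeps that core and carries tert-butyl in place of cyano on an aromatic carbon, para to a large group (tert-butyl in place of cyano on an aromatic carbon).

Among the measured compounds shown here, three measured steps bear on this change. They are a 1.0-fold lower number from compound 1 to compound 2 (0.02 log units; within the scatter), no change at the digits printed from compound 1 to compound 3 (within the scatter) and a 1.0-fold higher number from compound 2 to compound 3 (0.02 log units; within the scatter). Each exchanges one substituted phenyl group for another, and none of them moves the number in this assay beyond the scatter. For the measured compounds named here, none of the measured compounds carries tert-butyl, however, so the data do not test this group directly, and the range is kept wide.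

On these three compounds alone, the expected result is a 1.1-fold lower number from compound 1 to compound 4 (0.05 log units; within the scatter), which means no change beyond the scatter. For compound 4 the estimated value is 26000 nM, with an expected range of 13000 nM to 50000 nM.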

Compound 4, half-maximal inhibitory concentration: 9000 nM
The estimate for compound 4 lay 2.9-fold (0.46 log units) above the measured number, and the stated range ends above it.
By their numbers in this assay, from the lowest: compound 4; then compounds 2, 1 and 3 (each within the scatter of the next).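

In this assay, exchanging cyano for tert-butyl on the aromatic carbon gives a 3.2-fold lower number from compound 1 to compound 4 (0.51 log units; beyond the scatter) and is the only listed step in the series that lies beyond the scatter. The earlier exchanges among 4-cyanophenyl, 3,4-dichlorophenyl and 3-methoxyphenyl left the number within the scatter, so the flat picture from compounds 1, 2 and 3 does not extend to every group on this ring, and the position can respond to what it carries, though the step is modest. No measurement offered here bears on why the number moved.

With tert-butyl as the only group that shifts the number, the compounds shown cannot tell whether the shift belongs to this one group or extends to other carbon-only branched groups such as isopropyl or cyclopropyl at the same place, para to a large group. They also leave open how an amine or a carboxylic acid at that carbon would read in this assay and whether tert-butyl would give a similar shift at another place on the ring.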